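This account rests on a few compounds, and the source may have more. Where it says the series, first, only, none or still open, it means among the compounds named here.

Working notes on the series.

Within the data shown here, the set rests on a shared core, seen in compound 1 `CCN(CC)c1ccc2cc(C(=O)c3ccc(N4CCN(C(=O)CN5CCN(Cc6ccc(/C=C/C(=O)OC)cc6)CC5)CC4)cc3)oc2c1` and compound 2 `CCN(CC)c1ccc2cc(C(=O)c3ccc(N4CCN(C(=O)CN5CCN(Cc6ccc(F)c(F)c6)CC5)CC4)cc3)oc2c1`, with the group on the saturated chain carbon bound to the amine nitrogen in a ring as the only point of change. In a functional assay on HCT-116 cells (Homo sapiens) for cytotoxicity, read by MTT assay, with a stated time of 48 h (on this read-out higher numbers stand for weaker inhibition and lower numbers for stronger inhibition), compound 1 gives 9920 nM, and compound 2 gives 26300 nM. Among the measured compounds shown here, compound 2 stands as the highest of the two numbers; its nearest neighbour is compound 1, and the single step within the set, a 2.7-fold higher number from compound 1 to compound 2 (0.42 log units; beyond the scatter), is a swap of a benzyl-type group on that chain carbon.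

Compound 3 `CCN(CC)c1ccc2cc(C(=O)c3ccc(N4CCN(C(=O)CN5CCN(Cc6ccc(C(F)(F)F)cc6)CC5)CC4)cc3)oc2c1` is not yet measured. Against compound 2 the difference is 4-(trifluoromethyl)phenyl in place of 3,4-difluorophenyl on a saturated chain carbon bound to an amine nitrogen in a ring, so the same place on the chain carbon is touched as in the one step already recorded. For the measured compounds named here, that step bears on the new one only loosely: it shows that exchanging the aromatic ring at this position can move the number by a modest amount, but it involved a different pair of rings, and no step with a trifluoromethyl-bearing ring exists in the set. The expectation in this assay is therefore a step near or within the scatter from compound 2, a 1.5-fold lower number from compound 2 to compound 3 (0.16 log units; within the scatter), with direction uncertain. Compound 3 is accordingly estimated at 18000 nM, with a range from 7000 nM to 50000 nM.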

Compound 3, half-maximal inhibitory concentration: > 40000 nM
Compound 3: only a limit was reported (the forecaster's own chance of this, stated with the estimate: 10%); at least 2.2-fold (0.34 log units) between middle value and limit.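

Compound 3 is recorded in this assay only as a limit, not as a number: the limit of > 40000 nM in this assay, at which 1 of the 3 values shown sits.

Trifluoromethyl in place of 2-(methoxycarbonyl)ethenyl on an aromatic carbon gives an at least 4.0-fold higher number from compound 1 to compound 3 (0.60 log units; beyond the scatter), so both fluorine-bearing rings now read weaker than the ring of compound 1, which holds the strongest inhibition of the three, with both of its steps printed as beyond the scatter. From the compounds shown here alone, the change between the two fluorine-bearing rings gives an at least 1.5-fold higher number from compound 2 to compound 3 (0.18 log units; that floor lies within the scatter); this is only a floor, and its true size stays unknown, so the series does not yet show how far 4-(trifluoromethyl)benzyl departs from 3,4-difluorobenzyl.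

The compounds shown leave open whether the gain in compound 1 belongs to the 2-(methoxycarbonyl)ethenyl group as a whole or to a part of it, which the matching carboxylic acid, a saturated propanoate chain or a plain benzyl group would help to separate. They also leave open how a ring carrying an amine or a nitrile at the same place would read in this assay.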